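The source may hold more compounds than are shown below. What is called first, only, known or untested is meant among the compounds shown, and "the series" means these compounds.

Measured so far in a functional assay on MDA-MB-231 cells (Homo sapiens) for inhibition, read by CCK-8 assay, with a stated time of 48 h; a higher number here means a weaker inhibitor of growth, a lower number a stronger inhibitor of growth:
Compound 1 `Cc1ccccc1Nc1nc(NCc2ccncc2)ncc1Cl`: > 100000 nM, a limit of the assay.
Compound 2 `Cc1ccccc1Nc1nc(Nc2ccc(N3CCN(C)CC3)cc2)ncc1Cl`: 7020 nM.

For the measured compounds named here, compound 2 is the only compound with an actual number, since the other result is a limit. Compound 3 `Cc1ccccc1Nc1nc(Nc2ccc(N3CCCN(C)CC3)cc2)ncc1Cl` keeps the core of compound 2 and changes one group: 4-methyl-1,4-diazepan-1-yl in place of 4-methylpiperazin-1-yl on an aromatic carbon. Going by the values given here, no measured pair shows the effect of this swap, so the expectation rests on compound 2 at 7020 nM alone, and no clear direction is expected in this assay. The estimated change, a 1.1-fold lower number from compound 2 to compound 3 (0.03 log units; within the scatter), is expected to stay within the scatter. For compound 3 the estimated value is 6500 nM, with an expected range of 2500 nM to 16000 nM.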

Compound 3, concentration for 50% growth inhibition: 6390 nM
Compound 3: the middle estimate sits 1.0-fold (0.01 log units) above what was measured; measured number inside the range.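

In this assay, 4-methyl-1,4-diazepan-1-yl in place of 4-methylpiperazin-1-yl on the aromatic carbon gives a 1.1-fold lower number from compound 2 to compound 3 (0.04 log units; within the scatter). For the compounds shown here, at this position, the seven-membered ring therefore reads the same as the six-membered ring, which the earlier compounds could not show. No measured information at hand bears on this step.

Still open, going by these compounds, is how a morpholine ring, an open-chain amine or a carboxylic acid would read on this aromatic carbon. Also open, on these data alone, is what a longer chain in place of the methyl on the ring nitrogen would do.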